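The compounds below may be only part of what the source reports. "The series", "measured", "known", "first", "only" and "open" are said of these compounds alone.

In a functional assay on MDA-MB-231 cells (Homo sapiens) for antiproliferative activity, with a stated time of 5 days (a lower number here means a stronger inhibitor, a higher number a weaker inhibitor), compound 1 `O=C1C=CC2(C=C1)OCC(=O)N2c1nc(-c2ccc3ncccc3c2)nn1-c1ccccc1` gives 50 nM. Two relatives offer some context. Compound 3 `Cc1ccc(-n2nc(-c3ccc4ccccc4c3)nc2N2C(=O)COC23C=CC(=O)C=C3)cc1` gives 30 nM, which lies within the usual scatter of compound 1. Compound 2 `CC1CN(c2nc(-c3ccc4ccccc4c3)nn2-c2ccccc2)C2(C=CC(=O)C=C2)O1` gives 130 nM, a higher number than that of compound 1 and beyond the scatter, so it is the weaker inhibitor of that pair.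

The next compound is compound 4 `O=C1C=CC2(C=C1)OCC(=O)N2c1nc(-c2ccc3c(c2)OCCO3)nn1-c1ccccc1`, which keeps the shared core and the phenyl group of compound 1. For the measured compounds named here, only one group changes, on an aromatic carbon: 2,3-dihydro-1,4-benzodioxin-6-yl takes the place of quinolin-6-yl (2,3-dihydro-1,4-benzodioxin-6-yl in place of quinolin-6-yl on an aromatic carbon).

No two of the measured compounds differ in one place only, so none of them shows directly what a swap like this does. The expectation therefore has little to rest on. Compound 3 at 30 nM and compound 2 at 130 nM show the range seen so far in this small set, and neither carries the entering group. A small upward move in this assay seems the most likely outcome, and a result within the scatter would be no surprise. The expected step is a 1.6-fold higher number from compound 1 to compound 4 (0.20 log units; within the scatter). For compound 4 the estimated value is 80 nM, with an expected range from 25 nM to 250 nM.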

Compound 4, half-maximal inhibitory concentration: 100 nM
Estimate against measurement, compound 4: 1.3-fold (0.10 log units) below, within the range that was stated.
By their numbers in this assay, from the lowest: compounds 3, 1, 4 and 2 (each within the scatter of the next, the first and the last beyond it).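

In this assay, this position now has its first readable step (a 2.0-fold higher number from compound 1 to compound 4 (0.30 log units; within the scatter)), so with the shared core and the phenyl group kept, compound 1 and compound 4 cannot be told apart. The exchange is not a minor one on paper: quinolin-6-yl has an aromatic ring with one hetero atom, whereas 2,3-dihydro-1,4-benzodioxin-6-yl has a non-aromatic ring with two hetero atoms, and the hydrogen-bond acceptor count also differs between the two groups. In this one pair, then, an aromatic ring containing nitrogen is not required for a value within the scatter of compound 1, although no measurement shown explains why the two compounds read alike.

A single pair cannot show how far this position tolerates other kinds of group, and an amine, a carboxylic acid or a morpholine ring on the same aromatic carbon could read quite differently. On these data alone, it also remains open whether the same exchange would give a similar step on the core of compound 2, where the neighbouring structure is different.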